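The source may report more compounds than this note shows. Statements on the series, on what has been measured and on what is new or still open speak of the compounds shown alone.

In a functional assay on HeLa cells (Homo sapiens) for cytotoxicity, read by ELISA, with a stated time of 4 days (a higher number here means a weaker inhibitor, a lower number a stronger inhibitor), compound 1 (`Cc1ccsc1-c1cc(-c2ccco2)cc(-c2ccc(Cl)cc2)n1`) gives 24500 nM and compound 2 (`Cc1ccsc1-c1cc(-c2ccoc2)cc(-c2ccc(Cl)cc2)n1`) gives 17400 nM. Compound 3 (`Cc1ccsc1-c1cc(-c2ccc(Cl)o2)cc(-c2ccco2)n1`) gives 22200 nM, within the scatter of both other values. Compound 4 (`Cc1ccsc1-c1cc(-c2ccc(Cl)o2)cc(-c2ccc(Cl)cc2)n1`) has 4-chlorophenyl in place of furan-2-yl on an aromatic carbon of compound 3: 4-chlorophenyl in place of furan-2-yl on an aromatic carbon. Compound 4 keeps the 5-chlorofuran-2-yl group of compound 3, and the entering 4-chlorophenyl group is already present in compound 1 and compound 2. For the measured compounds named here, no measured step covers this exchange directly. The nearest evidence is a 1.4-fold lower number from compound 1 to compound 2 (0.15 log units; within the scatter), which concerns a different pair of groups and stays within the scatter. Going by the values given here, with only this one step and three values this close, no step beyond the scatter is expected in this assay, and the data give no basis for a direction. The estimated step is a 1.1-fold lower number from compound 3 to compound 4 (0.05 log units; within the scatter), which is expected to stay within the scatter. For compound 4 the estimated value is 20000 nM, with an expected range of 9000 nM to 40000 nM.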

Compound 4, half-maximal inhibitory concentration: 29300 nM
The estimate for compound 4 lay 1.5-fold (0.17 log units) below the measured number; low and high end bracket the measured number.
By their numbers in this assay, from the lowest: compounds 2, 3, 1 and 4 (each within the scatter of the next).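

Notes on the series: in this assay the position next to the ring nitrogen accepts 4-chlorophenyl in place of furan-2-yl with a 1.3-fold higher number from compound 3 to compound 4 (0.12 log units; within the scatter) and so tolerates a six-membered aromatic carbon ring as well as a five-membered aromatic ring with 1 hetero atom. On the group meta to the 3-methylthiophen-2-yl group, 5-chlorofuran-2-yl in place of furan-3-yl gives a 1.7-fold higher number from compound 2 to compound 4 (0.23 log units; within the scatter) and chloro in place of hydrogen gives a 1.2-fold higher number from compound 1 to compound 4 (0.08 log units; within the scatter) so neither change separates these compounds. No supporting information bears on this result.

All groups compared at both positions are aromatic rings, and the 3-methylthiophen-2-yl group stays constant throughout. Going by these compounds, whether an amine or a carboxylic acid at either varied position would give a step beyond the scatter remains open.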